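The source may report more compounds than this note shows. Statements on the series, on what has been measured and on what is new or still open speak of the compounds shown alone.

Compound 1 `CC(=O)OCCC(=O)O[C@H](CC=C(C)C)C1=CC(=O)c2c(O)ccc(O)c2C1=O` is one of three measured members of a shared core, and in a functional assay on DU-145 cells (Homo sapiens) for cytotoxicity, read by MTT assay (a higher number here means a weaker inhibitor, a lower number a stronger inhibitor), compound 1 gives 15700 nM. Compound 2 `CC(=O)OCCO[C@H](CC=C(C)C)C1=CC(=O)c2c(O)ccc(O)c2C1=O` gives 15500 nM in this assay, and compound 3 `CC(C)=CC[C@@H](OC(=O)CC(C)(O)C(C)C)C1=CC(=O)c2c(O)ccc(O)c2C1=O` gives 16900 nM. On these numbers compound 1 stands second highest, with compound 2 nearest: a 1.0-fold lower number from compound 1 to compound 2 (0.01 log units; within the scatter). Compound 3 is furthest from it: a 1.1-fold higher number from compound 1 to compound 3 (0.03 log units; within the scatter). The remaining pair is just as close: a 1.1-fold higher number from compound 2 to compound 3 (0.04 log units; within the scatter). All three numbers therefore sit together.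

Compound 4 `CC(C)=CC[C@@H](OCCO)C1=CC(=O)c2c(O)ccc(O)c2C1=O` differs from compound 1 at the same oxygen on a saturated carbon that was altered in compound 2: 2-hydroxyethyl in place of (2-acetoxyethyl)carbonyl on an oxygen on a saturated carbon. The step that bears on this is a 1.0-fold lower number from compound 1 to compound 2 (0.01 log units; within the scatter), where the (2-acetoxyethyl)carbonyl group was likewise exchanged and the number did not move beyond the scatter; the step to compound 3, a 1.1-fold higher number from compound 1 to compound 3 (0.03 log units; within the scatter), also changed a group at this position without effect. Compound 4 is therefore expected to stay where compound 1 stands, a 1.0-fold lower number from compound 1 to compound 4 (0.01 log units; within the scatter), and its estimated value in this assay is 15500 nM, within a range of 7000 nM to 35000 nM.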

Compound 4, half-maximal inhibitory concentration: 9900 nM
Compound 4: middle estimate off by 1.6-fold (0.19 log units), on the high side; the range from low to high includes it.
By their numbers in this assay, from the lowest: compounds 4, 2, 1 and 3 (each within the scatter of the next).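

In this assay, shortening the group on this oxygen from the 8 heavy atoms of (2-acetoxyethyl)carbonyl to the 3 of 2-hydroxyethyl gives a 1.6-fold lower number from compound 1 to compound 4 (0.20 log units; within the scatter), and the comparison with the other ester gives a 1.7-fold lower number from compound 3 to compound 4 (0.23 log units; within the scatter). Taking the acetyl off the ether of compound 2 to leave hydrogen, a change the earlier compounds did not include, gives a 1.6-fold lower number from compound 2 to compound 4 (0.19 log units; within the scatter), so across the four compounds this position accepts ester or ether links, a capped or free end hydroxyl and a much smaller group, all without a step beyond the scatter. No supporting data bear on this result.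

Going by these compounds, whether an amine or a carboxylic acid at the end of the 2-hydroxyethyl group, or a longer chain on this oxygen, would move the number beyond the scatter stays open. On these data alone, whether the same flat picture holds in other cell lines also stays open.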